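The compounds below may be only part of what the source reports. "The series", "measured", "known", "first", "only" and "open" are said of these compounds alone.

Working notes on the series. Among the compounds with values here, compound 1 `Cc1cc(N2CCN(C(C)C)CC2)nc2ccc(NC(=O)c3ccc(Cl)c(Cl)c3)cc12` is the first point of reference; in a functional assay on SK-BR-3 cells (Homo sapiens) for antiproliferative activity, read by MTT assay, with a stated time of 72 h (a higher number here means a weaker inhibitor, a lower number a stronger inhibitor), compound 1 gives 6680 nM. Compound 2 `CCN1CCN(c2cc(C)c3cc(NC(=O)c4ccco4)ccc3n2)CC1` carries furan-2-yl on a carbonyl carbon, and in this assay compound 2 gives 37500 nM. Compound 3 `CCN1CCN(c2cc(C)c3cc(NC(=O)c4ccc[nH]4)ccc3n2)CC1` carries 1H-pyrrol-2-yl in that place; in this assay compound 3 gives 13200 nM. Within the data shown here, the one single-point step measured so far is a 2.8-fold lower number from compound 2 to compound 3 (0.45 log units; beyond the scatter). Compound 1 has the lowest of the three numbers; compound 3 lies within the scatter of it, compound 2 beyond it.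

Compound 4 `Cc1cc(N2CCN(C)CC2)nc2ccc(NC(=O)c3ccc(Cl)c(Cl)c3)cc12` differs from compound 1 in one place only: methyl in place of isopropyl on an amine nitrogen in a ring. Among the measured compounds shown here, no measured step touches the group on that amine nitrogen in a ring; the only step in hand concerns the group on the carbonyl carbon, which compound 4 shares with compound 1. For compound 4 the expected step is therefore a 1.0-fold lower number from compound 1 to compound 4 (0.01 log units; within the scatter), nothing beyond the scatter. Compound 4 is estimated at 6500 nM, with a range from 2500 nM to 17000 nM.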

Compound 4, half-maximal inhibitory concentration: 6320 nM
The estimate for compound 4 lay 1.0-fold (0.01 log units) above the measured number; measured number inside the range.
By their numbers in this assay, from the lowest: compounds 4, 1 and 3 (each within the scatter of the next, the first and the last beyond it); then compound 2.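

Within the data shown here, the step on the amine nitrogen in a ring, a 1.1-fold lower number from compound 1 to compound 4 (0.02 log units; within the scatter) in this assay, is the first measured at this position, and it stays within the scatter. With the rest of compound 1 unchanged, isopropyl and methyl on that nitrogen cannot be told apart by this read-out, so the two alkyl groups give no handle on the number here. Nothing in hand bears on why this step is so small.

Still open, as far as these compounds go, is whether a group of another kind on that nitrogen, such as benzyl, a hydroxyethyl chain or a plain hydrogen, would separate from isopropyl and methyl in the same way or give a step beyond the scatter. Also open, from the compounds shown here alone, is whether a longer chain there, ending in an amine or a carboxylic acid, would move the number at all.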